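Bromo for chloro, repeated on a second core

The source may report more compounds than this note shows. Statements on the series, on what has been measured and on what is new or still open speak of the compounds shown alone.

Compound 1 `O=C(/C=C/c1ccc(Cl)cc1)NS(=O)(=O)c1ccc(Cl)cc1` gives 2.5 ug/mL in a functional assay on B16-F10 cells (Mus musculus) for antiproliferative activity, read by ELISA and MTT assay, with a stated time of 48 h; a lower number here means a stronger inhibitor, a higher number a weaker inhibitor. Compound 2 `O=C(/C=C/c1ccc(Cl)cc1)NS(=O)(=O)c1ccc(Br)cc1` carries the change bromo in place of chloro on an aromatic carbon and gives 2.8 ug/mL in this assay, so the step of a 1.1-fold higher number from compound 1 to compound 2 (0.05 log units; within the scatter) is a small one. Compound 3 `COc1ccc(/C=C/C(=O)NS(=O)(=O)c2ccc(Cl)cc2)cc1` differs from compound 1 by methoxy in place of chloro on an aromatic carbon; in this assay compound 3 gives 5.3 ug/mL, and the step of a 2.1-fold higher number from compound 1 to compound 3 (0.33 log units; beyond the scatter) is the only one among these three that reaches beyond the usual scatter.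

Compound 4 `COc1ccc(/C=C/C(=O)NS(=O)(=O)c2ccc(Br)cc2)cc1` has not yet been measured. It stands to compound 3 as compound 2 stands to compound 1: the change bromo in place of chloro on an aromatic carbon is the same change, at the same place, on a core that differs by the methoxy group just described. Within the data shown here, the one earlier instance of this change, the step from compound 1 to compound 2, barely moved the number, so the expectation for compound 4 rests on that step a 1.1-fold higher number from compound 1 to compound 2 (0.05 log units; within the scatter) and on the value of compound 3 5.3 ug/mL as its starting point. For compound 4 the expected step in this assay is a 1.1-fold higher number from compound 3 to compound 4 (0.04 log units; within the scatter), essentially flat. Among the measured compounds shown here, compound 4 is therefore estimated at 5.8 ug/mL in this assay, with a range from 3 ug/mL to 11 ug/mL to allow for ordinary scatter and for the single precedent on which the expectation rests.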

Compound 4, half-maximal inhibitory concentration: 5.8 ug/mL
Estimate against measurement, compound 4: no gap at the digits printed; low and high end bracket the measured number.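

In this assay, bromo in place of chloro stays essentially flat on the methoxy core, with a 1.1-fold higher number from compound 3 to compound 4 (0.04 log units; within the scatter), and this step matches the earlier one on the core of compound 1: the same change on two cores in this assay, a 1.1-fold higher number (0.05 log units; within the scatter) from compound 1 to compound 2 and a 1.1-fold higher number (0.04 log units; within the scatter) from compound 3 to compound 4, 1.0-fold (0.01 log units) apart, within the scatter of two such steps The methoxy for chloro change also carries across, now on the 4-bromophenyl side of the molecule, with a 2.1-fold higher number from compound 2 to compound 4 (0.32 log units; beyond the scatter), a modest step of the same size as on the 4-chlorophenyl side: the same change on two cores in this assay, a 2.1-fold higher number (0.33 log units; beyond the scatter) from compound 1 to compound 3 and a 2.1-fold higher number (0.32 log units; beyond the scatter) from compound 2 to compound 4, 1.0-fold (0.01 log units) apart, within the scatter of two such steps Across these four compounds the two changes therefore read as independent of each other, but each comparison rests on a single pair of cores in this assay, and the result says neither why the numbers move nor whether other groups would behave the same way.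

As far as these compounds go, only chloro and bromo appear at the place changed in compound 4, and only chloro and methoxy at the other varied place, so the effect of an amine, a carboxylic acid or a fluoro at either place remains open. Also open, from the compounds shown here alone, is what a longer chain between the carbonyl and the chlorophenyl or methoxyphenyl group would do, and what a methyl in place of the amide hydrogen would do.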